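A few compounds are considered here, and "the series" means these few. Any claim that something is new, unique, unknown or untested is made for them only; others in the source may bear on it.

Compounds measured so far:
Compound 1 `CCC(C)(C)Cc1c[nH]c(CCc2ccc(-c3csnn3)cc2)n1`: 45 nM
Compound 2 `CCC(C)(C)Cc1c[nH]c(CCc2ccc(-c3cccnc3)cc2)n1`: 7.5 nM

Both were tested in an in vitro assay on CHO cells for displacement of a labelled ligand from Bombesin receptor subtype-3 (Homo sapiens), read by scintillation counting, with a stated time of 2 h; on this read-out higher numbers stand for weaker inhibition and lower numbers for stronger inhibition. Going by the values given here, compound 2 holds the lower of the two numbers; the single measured step, a 6.0-fold lower number from compound 1 to compound 2 (0.78 log units; beyond the scatter), separates it from compound 1, and that gap is beyond the scatter.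

Compound 3 `CCC(C)(C)Cc1c[nH]c(CCc2ccc(-c3ccccc3C(=O)O)cc2)n1` is not yet measured. It differs from compound 2 in one place: 2-carboxyphenyl in place of pyridin-3-yl on an aromatic carbon. Among the compounds with values here, the only step on record bears on this change just loosely, since it exchanged one small heteroaromatic ring for another at the same position, whereas the new group is a carbon-only ring carrying a hydrogen-bond donor and a double bond outside aromatic rings, features neither measured compound has. Within the data shown here, the change from compound 1 to compound 2 shows that this position is sensitive to the identity of the ring, so a step beyond the scatter is plausible, and with no donor-bearing precedent a weaker result seems the more cautious expectation, with wide uncertainty in both directions. The expected step is a 4.0-fold higher number from compound 2 to compound 3 (0.60 log units; beyond the scatter). Compound 3 is therefore estimated at 30 nM in this assay, within a range of 8 nM to 150 nM.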

Compound 3, half-maximal inhibitory concentration: 11 nM
Compound 3: middle estimate off by 2.7-fold (0.44 log units), on the high side; measured number inside the range.
By their numbers in this assay, from the lowest: compounds 2 and 3 (each within the scatter of the next); then compound 1.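

In this assay, the exchange gives a 1.5-fold higher number from compound 2 to compound 3 (0.17 log units; within the scatter), so on this aromatic carbon, para to a large group, pyridin-3-yl and the larger 2-carboxyphenyl cannot be told apart, even though the latter brings a hydrogen-bond donor and a double bond outside aromatic rings. The earlier compounds shown here showed only that the position responds to an exchange of one heteroaromatic ring for another; the new compound shows that a hetero atom in the six-membered aromatic ring is not needed to stay clear of compound 1, with a 4.1-fold lower number from compound 1 to compound 3 (0.61 log units; beyond the scatter). Nothing available explains why these two different groups read alike.

The compounds shown leave open whether a plain phenyl, a methyl ester or a primary amide would read the same as 2-carboxyphenyl, so the contribution of the carbon-only ring cannot yet be separated from that of the carboxylic acid it carries. Also open, going by these compounds, is how far this position stretches, for example to an amine on that ring or to a longer chain carrying the carboxylic acid.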